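The source may report more compounds than this note shows. Statements on the series, on what has been measured and on what is new or still open speak of the compounds shown alone.

Measured so far in a functional assay on OVCAR-8 cells (Homo sapiens) for inhibition, read by sulforhodamine B assay, with a stated time of 48 h; a higher number here means a weaker inhibitor of growth, a lower number a stronger inhibitor of growth:
- compound 1 `Cc1ccc(C2=NN(c3ccc(S(C)(=O)=O)cc3)C(=O)CC2)cc1` gives 740 nM
- compound 2 `Cc1cc(O)ccc1C1=NN(c2ccc(S(C)(=O)=O)cc2)C(=O)CC1` gives 12300 nM

Compound 2 has the higher of the two numbers, which makes it the weaker inhibitor of growth of this pair. Within the data shown here, the only measured step is a 17-fold higher number from compound 1 to compound 2 (1.22 log units; beyond the scatter), large and beyond the scatter, with 4-hydroxy-2-methylphenyl in place of 4-methylphenyl on a carbon with a double bond to nitrogen.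

Compound 3 `CCc1ccc(C2=NN(c3ccc(S(C)(=O)=O)cc3)C(=O)CC2)cc1` has not been measured. The change to it is 4-ethylphenyl in place of 4-hydroxy-2-methylphenyl on a carbon with a double bond to nitrogen, with 4-ethylphenyl in place of 4-hydroxy-2-methylphenyl at that same carbon. This removes the group that compound 2 introduced, but it leaves 4-ethylphenyl instead of the 4-methylphenyl of compound 1 . Among the measured compounds shown here, no measured step covers that last difference, so the range is kept wide. Given the large step of a 17-fold higher number from compound 1 to compound 2 (1.22 log units; beyond the scatter), a large step toward a lower number is expected in this assay, roughly reversing it. The expected step is a 14-fold lower number from compound 2 to compound 3 (1.14 log units; beyond the scatter). For compound 3 the estimated value is 900 nM, with an expected range of 300 nM to 2700 nM.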

Compound 3, concentration for 50% growth inhibition: 3250 nM
For compound 3 the middle estimate is 3.6-fold (0.56 log units) below the measured one; measured number outside the range, above it.
By their numbers in this assay, from the lowest: compound 1; then compound 3; then compound 2.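

In this assay the step of a 4.4-fold higher number from compound 1 to compound 3 (0.64 log units; beyond the scatter) shows that this position responds to a single methyl in place of hydrogen on the saturated chain carbon bound to the aromatic carbon, with no hydroxy group involved. The step of a 3.8-fold lower number from compound 2 to compound 3 (0.58 log units; beyond the scatter) shows that removing 4-hydroxy-2-methylphenyl in favour of 4-ethylphenyl regains only part of the ground separating compound 2 from compound 1, so the large penalty seen earlier cannot be read as specific to the hydroxy-bearing ring. No measurement on hand accounts for either step.

As far as these compounds go, since the hydroxy group and the added ring methyl enter together in compound 2, their separate contributions stay open, and a phenyl ring carrying only one of them would be needed to tell them apart. Also open, from the compounds shown here alone, is whether a propyl chain, a methoxy group or a chlorine in place of the ethyl group would continue the rise in the number seen on going from methyl to ethyl.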